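Cytotoxicity notes on a bis-benzylidene series with triazole side chains

The compounds below may be only part of what the source reports. "The series", "measured", "known", "first", "only" and "open" are said of these compounds alone.

Measured compounds:
- compound 1 `COc1ccc(/C=C2\CN(C(=S)SCc3cn(Cc4ccccc4F)nn3)C/C(=C\c3ccc(OC)cc3)C2=O)cc1`: "not determined" (no result reported)
- compound 2 `COc1ccc(/C=C2\CN(C(=S)SCc3cn(Cc4ccc(F)cc4)nn3)C/C(=C\c3ccc(OC)cc3)C2=O)cc1`: "not determined" (no result reported)
- compound 3 `O=C1/C(=C/c2ccccc2F)CN(Cc2cn(Cc3cccc(Cl)c3)nn2)C/C1=C\c1ccccc1F`: 33100 nM

In an ADME assay on HEK293 cells (Homo sapiens) for cytotoxicity, read by MTT assay, with a stated time of 24 h (a lower number here means a stronger inhibitor, a higher number a weaker inhibitor), compound 1 gives "not determined" (no result reported). Compound 2 likewise gives "not determined" (no result reported) in this assay, so compound 2 stands without any number of its own, and the only figure in the set comes from compound 3, which in this assay gives 33100 nM. Compound 3 shares the triazole-linked benzyl side chain with the others but carries fluorines on its outer aromatic rings and no thiocarbonyl, so its value is a rough anchor only.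

Compound 4 `COc1ccc(/C=C2\CN(C(=S)SCc3cn(Cc4cccc(Cl)c4)nn3)C/C(=C\c3ccc(OC)cc3)C2=O)cc1` is the next entry. It differs from compound 2 in one place: 3-chlorophenyl in place of 4-fluorophenyl on a saturated chain carbon bound to an aromatic nitrogen. For the measured compounds named here, no step between measured compounds covers this exchange, and compound 2 itself has no number, so no size or direction can be read for this assay; the change is expected to sit within the scatter rather than beyond it, with weak cytotoxicity resembling that of compound 3.

Compound 4 is therefore expected to give about 30000 nM in this assay, with a plausible span from 10000 nM to 90000 nM.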

Compound 4, half-maximal inhibitory concentration: > 100000 nM
Compound 4: a limit, no number; the forecaster's own chance of this, stated with the estimate: 35%; at least 3.3-fold (0.52 log units) between middle value and limit.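

In this assay compound 4 gives > 100000 nM, which is a limit and not a number. Compound 2 stands without a number of its own, so no step can be read for the pair of compound 2 and compound 4. The compounds shown leave open whether exchanging 4-fluorophenyl for 3-chlorophenyl changes the cytotoxicity reading at all.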